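A few compounds are considered here, and "the series" means these few. Any claim that something is new, unique, unknown or untested is made for them only; others in the source may bear on it.

Working notes on the series, read in an in vivo ADME assay on the whole organism (strain 129/SvEvBrd x C57BL/6) for pharmacokinetics, with Mus musculus as the target, at a dose of 1 mg/kg by the intravenous route (on this read-out higher numbers stand for fast clearance and lower numbers for slow clearance), throughout. Compound 1 (`CCc1[nH]c(C(C)=O)nc1[C@@H](O)[C@H](O)[C@H](O)CO`) gives 17.3 mL/min/kg here, compound 2 (`CN(C)C(=O)c1nc([C@@H](O)[C@H](O)[C@H](O)CO)c[nH]1`) gives 11.3 mL/min/kg here, and compound 3 (`Cc1nc(-c2nc([C@@H](O)[C@H](O)[C@H](O)CO)c[nH]2)cs1`) gives 19.4 mL/min/kg here. Compound 3 holds no distinct place on these numbers, since all three values lie within the scatter of one another.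

The next change leads to compound 4 (`OC[C@@H](O)[C@@H](O)[C@H](O)c1c[nH]c(-c2cocn2)n1`). It puts 1,3-oxazol-4-yl in place of 2-methyl-1,3-thiazol-4-yl on an aromatic carbon, and the count for it reads 1,3-oxazol-4-yl in place of 2-methyl-1,3-thiazol-4-yl on an aromatic carbon at this place.

Among the compounds with values here, only one measured step concerns the same place. That step, a 1.7-fold higher number from compound 2 to compound 3 (0.23 log units; within the scatter) in the same read-out, exchanged dimethylcarbamoyl for 2-methyl-1,3-thiazol-4-yl. Within the data shown here, no measured step covers the exact exchange at hand, so the guide is indirect. Even so, a larger exchange of groups at this carbon stayed within the scatter, so no direction is favoured in this assay and nothing beyond the scatter is expected. The expected move, a 1.2-fold lower number from compound 3 to compound 4 (0.08 log units; within the scatter) as estimated, stays within the scatter too. Compound 4 is estimated at 16 mL/min/kg with an expected range from 8 mL/min/kg to 32 mL/min/kg for the coming measurement.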

Compound 4, clearance: 16.6 mL/min/kg
Compound 4: the middle estimate sits 1.0-fold (0.02 log units) below what was measured, within the range that was stated.
By their numbers in this assay, from the lowest: compounds 2, 4, 1 and 3 (each within the scatter of the next).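

In this assay, within the data shown here, the exchange of one five-membered aromatic ring for another at this carbon, read directly, gives a 1.2-fold lower number from compound 3 to compound 4 (0.07 log units; within the scatter); the earlier compounds offered only an exchange involving dimethylcarbamoyl at this place. With a 1.5-fold higher number from compound 2 to compound 4 (0.17 log units; within the scatter) as a second reading against dimethylcarbamoyl, compounds 2, 3 and 4 now all lie within the scatter of one another, so neither 1,3-oxazol-4-yl nor 2-methyl-1,3-thiazol-4-yl separates from dimethylcarbamoyl on this read-out, and the loss of the methyl-bearing thiazole in favour of the oxazole leaves the reading within the scatter as well. No supporting evidence bears on why these three compounds read alike.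

From the compounds shown here alone, every group compared at this carbon is uncharged and has no hydrogen-bond donor, so it remains open whether a primary amine, a carboxylic acid or a longer alkyl chain at the same place would move clearance beyond the scatter. Going by these compounds, it also remains open whether a change to the group of 8 heavy atoms on the same ring, rather than at this carbon, would do so.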